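Replacing a Sulfur-Containing Ring on the Thiourea Sulfur Arm

The source may hold more compounds than are shown below. What is called first, only, known or untested is meant among the compounds shown, and "the series" means these compounds.

Three compounds share a thiosemicarbazide-type core and were tested in a functional assay on HeLa cells (Homo sapiens) for cytotoxicity, read by MTT assay, with a stated time of 72 h, tested at 10 uM; on this read-out lower numbers stand for less inhibition of growth and higher numbers for more inhibition of growth at the one concentration tested. Compound 1 `Cc1ccnc(/C(N)=N/NC(=S)N2CCSCC2)c1` gives 39.2% in this assay, compound 2 `N/C(=N\NC(=S)N1CCSCC1)c1ccccn1` gives 54.5%, and compound 3 `Cc1cccc(/C(N)=N/NC(=S)N2CCN(c3ccccn3)CC2)n1` gives 72.8%. Compound 2 stands second highest of the three, between compound 1 and compound 3.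

Among the measured compounds shown here, the only step measured between compounds differing in one place is a number 15.3 percentage points higher from compound 1 to compound 2 (beyond the scatter). For the measured compounds named here, compound 3 differs from compound 2 in more than one place, so its value offers no isolated step.

Compound 4 `N/C(=N\NC(=S)N1CCCCC1)c1ccccn1` differs from compound 2 as follows. piperidin-1-yl in place of thiomorpholin-4-yl on a thiocarbonyl carbon

Going by the values given here, no measured step touches the ring on the thiocarbonyl carbon; the one known step concerns the methyl on the aromatic ring and therefore does not bear on this change. With nothing to indicate a direction, the expected step in this assay is a number 0.5 percentage points lower from compound 2 to compound 4 (within the scatter), which is no change beyond the scatter. Compound 4 is therefore expected to give 54% in this assay, in the range 36% to 70%.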

Compound 4, percent growth inhibition at one concentration: 55.7%
Estimate against measurement, compound 4: 1.7 percentage points below, within the range that was stated.
By their numbers in this assay, from the lowest: compound 1; then compounds 2 and 4 (each within the scatter of the next); then compound 3.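

In this assay, among the compounds shown here, putting piperidin-1-yl in place of thiomorpholin-4-yl on the thiocarbonyl carbon gives a number 1.2 percentage points higher from compound 2 to compound 4 (within the scatter), the first measured step at this position. The ring sulfur can therefore be exchanged for carbon here with no change beyond the scatter, so at the one concentration tested, this read-out does not depend on that sulfur in this pair. No independent measurement bears on why the two rings read alike.

Going by these compounds, whether this position would stay as undisturbed with a morpholin-4-yl ring or an open-chain diethylamino group on the thiocarbonyl carbon remains open. So does whether the step seen for hydrogen in place of methyl on an aromatic carbon would carry over to compounds bearing piperidin-1-yl.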